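A few compounds are considered here, and "the series" means these few. Any claim that something is new, unique, unknown or untested is made for them only; others in the source may bear on it.

Measured in an ADME assay on HCT-116 cells (Homo sapiens) for cytotoxicity, read by CellTiter-Glo, with a stated time of 72 h; on this read-out higher numbers stand for weaker inhibition and lower numbers for stronger inhibition:
- Compound 1 `Cc1noc(C)c1S(=O)(=O)N1CCC(N2CCC(C)CC2)CC1`: > 10000 nM, a limit
- Compound 2 `CC1CCN(C2CCN(S(=O)(=O)c3ccccc3Br)CC2)CC1`: > 5000 nM, a limit
- Compound 3 `COc1cccc(S(=O)(=O)N2CCC(N3CCC(C)CC3)CC2)c1`: > 5000 nM, a limit

Compound 3 has no numerical value, only the limit > 5000 nM. This is the limit of > 5000 nM in this assay, at which 2 of the 3 values shown sit, while the other limit in the series is the limit of > 10000 nM in this assay, at which 1 of the 3 values shown sits.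

Compound 4 `Cc1nc(Cl)sc1S(=O)(=O)N1CCC(N2CCC(C)CC2)CC1` carries 2-chloro-4-methyl-1,3-thiazol-5-yl in place of 3-methoxyphenyl on a sulfonyl sulfur.

Among the measured compounds shown here, three measured steps bear on this change, since each also replaces the group on the sulfonyl sulfur: a step that the two limits leave unreadable from compound 1 to compound 2, a step that the two limits leave unreadable from compound 1 to compound 3 and a step that the two limits leave unreadable from compound 2 to compound 3. None of them has a readable size, so they give no direction for the new step in this assay. No step beyond the scatter is therefore expected, and the estimated step is a step that the limit leaves unreadable from compound 3 to compound 4. A further limit is the most likely report. For compound 4 the expected value is 7000 nM, with an estimated range from 2000 nM to 20000 nM.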

Compound 4, half-maximal inhibitory concentration: > 10000 nM
Compound 4: only a limit was reported (the forecaster's own chance of this, stated with the estimate: 75%); at least 1.4-fold (0.15 log units) between middle value and limit.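

Compound 4 gives > 10000 nM, which is a limit, so its steps from compound 1, compound 2 and compound 3 cannot be read. The compounds shown leave open whether the group on the sulfonyl sulfur alters the result in this assay at all.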